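The source may hold more compounds than are shown below. What is called first, only, known or untested is meant among the compounds shown, and "the series" means these compounds.

In a functional assay on BGC-823 cells (Homo sapiens) for inhibition, read by CCK-8 assay, with a stated time of 48 h (on this read-out lower numbers stand for stronger inhibition and higher numbers for weaker inhibition), compound 1 `Cc1ccc(C2=NN(C3=NC(=O)CS3)C(c3ccc4ccccc4c3)C2)cc1` gives 7790 nM, the smallest of the three numbers, yet its gaps to compound 2 `Cc1ccc(C2=NN(C3=NC(c4ccccc4)CS3)C(c3ccc4ccccc4c3)C2)cc1` at 8940 nM and compound 3 `Cc1ccc(C2=NN(C3=NC(=O)CS3)C(c3cccc4ccccc34)C2)cc1` at 10000 nM both lie within the usual scatter, so no order among them can be claimed. For the measured compounds named here, the one measured step, a 1.1-fold higher number from compound 1 to compound 2 (0.06 log units; within the scatter), changes the group on the amine nitrogen in a ring and leaves the read-out essentially unchanged. Compound 4 `Cc1ccc(C2=NN(C3=NC(=O)CS3)C(c3ccc4ccccc4c3)C2)cc1C` differs from compound 1 by methyl in place of hydrogen on an aromatic carbon. Going by the values given here, no measured step touches this place, so nothing here predicts a shift, and the step of a 1.0-fold lower number from compound 1 to compound 4 (0.02 log units; within the scatter) is expected to stay within the scatter. Compound 4 is therefore estimated at 7500 nM, with a range from 3500 nM to 16000 nM.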

Compound 4, half-maximal inhibitory concentration: 6020 nM
Beside the measured number, compound 4's estimate is 1.2-fold (0.10 log units) above it; the range from low to high includes it.
By their numbers in this assay, from the lowest: compounds 4, 1, 2 and 3 (each within the scatter of the next).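

In this assay, going from 4-methylphenyl to 3,4-dimethylphenyl gives a 1.3-fold lower number from compound 1 to compound 4 (0.11 log units; within the scatter) and so shows that this aromatic carbon, ortho to a methyl group, can carry one added methyl with no change that stands out from the scatter. No measurement here offers an explanation for this result. One methyl group says little about other substituents at this position. From the compounds shown here alone, whether an amine, a carboxylic acid or a longer chain would leave the read-out just as unchanged remains open.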